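Swapping butyl for methoxy on a sulfonamide series

A few compounds are considered here, and "the series" means these few. Any claim that something is new, unique, unknown or untested is made for them only; others in the source may bear on it.

Three compounds have been measured in a functional assay on MCF7 cells (Homo sapiens) for antiproliferative activity, read by sulforhodamine B assay, with a stated time of 48 h; a lower number here means a stronger inhibitor, a higher number a weaker inhibitor:

Compound 1 `CCCCc1ccc(NS(=O)(=O)c2ccc(N3CCNC3=O)cc2)cc1` gives 770 nM in this assay.
Compound 2 `O=C1NCCN1c1ccc(S(=O)(=O)Nc2ccc(F)c(F)c2)cc1` gives 620 nM in this assay.
Compound 3 `Cc1cccc(NS(=O)(=O)c2ccc(N3CCNC3=O)cc2)c1C` gives 230 nM in this assay.

All three share the same core and differ only in the aryl group on the sulfonamide nitrogen. Compound 1 has the highest number of the three; its gap to compound 2 lies within the scatter, while compound 3 sits beyond it with the lowest number. Among the compounds with values here, the one step that differs in a single place is a 2.7-fold lower number from compound 2 to compound 3 (0.43 log units; beyond the scatter).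

The next compound, compound 4 `COc1ccc(NS(=O)(=O)c2ccc(N3CCNC3=O)cc2)cc1`, differs from compound 1 in one place: methoxy in place of butyl on an aromatic carbon. Within the data shown here, no measured step exchanges one substituent for another at this position, and the step from compound 2 to compound 3 concerns different groups, so no direct guide exists. The spread among the three measured compounds is modest, and a change of similar size seems the most plausible outcome.

Compound 4 is therefore expected to fall near 600 nM, within 200 nM to 2000 nM, which amounts to an expected step of a 1.3-fold lower number from compound 1 to compound 4 (0.11 log units; within the scatter).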

Compound 4, half-maximal inhibitory concentration: > 1000 nM
Compound 4 ended at the assay's limit; the forecaster's own chance of this, stated with the estimate: 5%; middle value at least 1.6-fold (0.22 log units) away from the limit.
By their numbers in this assay, from the lowest: compound 3; then compounds 2 and 1 (each within the scatter of the next). At a limit, above all of these: compound 4.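

(Compound 4 reads as a limit, not as a number: the limit of > 1000 nM in this assay, at which 1 of the 4 values shown sits) Methoxy in place of butyl on this aromatic carbon gives an at least 1.2-fold higher number from compound 1 to compound 4 (0.11 log units; that floor lies within the scatter), a floor that does not by itself show a real loss, and the same holds for an at least 1.6-fold higher number from compound 2 to compound 4 (0.20 log units; that floor lies within the scatter). Within the data shown here, the one firm reading is an at least 4.3-fold higher number from compound 3 to compound 4 (0.63 log units; beyond the scatter), so 4-methoxyphenyl on the sulfonamide nitrogen gives a weaker inhibitor than 2,3-dimethylphenyl, and the shorter group does not bring compound 4 anywhere near compound 3.

From the compounds shown here alone, how far past the limit compound 4 truly lies remains open, so the real size of the butyl-to-methoxy change is unknown. Also open, going by these compounds, is whether a hydroxyl, an amine or a chain longer than butyl at this same position would shift the number in either direction.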